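Swapping the aryl group on a trimethoxyphenyl oxadiazoline

A few compounds are considered here, and "the series" means these few. Any claim that something is new, unique, unknown or untested is made for them only; others in the source may bear on it.

Of the compounds shown here, two from this study have been measured in a functional assay on BGC-823 cells (Homo sapiens) for antiproliferative activity, read by MTT assay, tested at 5 uM; on this read-out higher numbers stand for a stronger effect at the one concentration tested and lower numbers for a weaker effect. Compound 1 `COc1cc(C2=NN(C(C)=O)C(c3ccc(F)cc3)O2)cc(OC)c1OC` gives 13.3% in this assay, the lower of the two numbers recorded. Compound 2 `COc1cc(C(=O)N/N=C/c2ccccc2F)cc(OC)c1OC` gives 76.5% in this assay, a result that lies beyond the scatter of the method above compound 1. Going by the values given here, the two structures differ in several places at once, so no single step between them can be traced.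

Compound 3 `COc1cc(C2=NN(C(C)=O)C(c3ccc(Cl)c([N+](=O)[O-])c3)O2)cc(OC)c1OC` is not yet measured. It differs from compound 1 in one place: 4-chloro-3-nitrophenyl in place of 4-fluorophenyl on a saturated ring carbon. Among the compounds with values here, nothing among the measured compounds follows a comparable exchange on a saturated ring carbon, so there is no step on which to base a firm prediction; the nearest anchor is compound 1 itself at 13.3%.

In this situation a modest change is expected, if any, with the step of a number 6.7 percentage points higher from compound 1 to compound 3 (within the scatter) estimated to stay close to the scatter of the method. Compound 3 is therefore estimated at 20% in this assay, within a range from 5% to 45%.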

Compound 3, a percentage reported as inhibition, at one concentration (the size of the read-out at that concentration, not a potency): 0%
Beside the measured number, compound 3's estimate is 20 percentage points above it; the whole stated range lies above it.
By their numbers in this assay, from the lowest: compound 3; then compound 1; then compound 2.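

Swapping 4-fluorophenyl for 4-chloro-3-nitrophenyl on the saturated ring carbon gives the first step in this series that can be traced to a single place: in this assay it is a number 13.3 percentage points lower from compound 1 to compound 3 (beyond the scatter). It shows that the read-out responds to the aryl group at this carbon, and that this larger group, which brings two hydrogen-bond acceptors, does not raise a number that was already low, as compound 3 gives 0%. No measurement shown here bears on the reason for this step.

The compounds shown leave open which part of the new group goes with the step, as the chlorine and the nitro group enter together and only a 4-chlorophenyl or a 3-nitrophenyl on the same carbon would separate them. They also leave open whether any aryl group at this carbon can lift the number towards that of compound 2, which differs from the oxadiazoline compounds in several places, and a 4-aminophenyl or a 4-methoxyphenyl would test this position further.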